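Cytotoxicity notes: fluoro-cyano aryl swap on compound 3

A few compounds are considered here, and "the series" means these few. Any claim that something is new, unique, unknown or untested is made for them only; others in the source may bear on it.

Measured in a toxicity assay on MT4 cells (Homo sapiens) for cytotoxicity, read by MTT assay; a higher number here means that more compound is tolerated, a lower number that less compound is tolerated:
compound 1 `Cc1cc(-c2ccc(C#N)c(C#N)c2)ccc1Oc1cc(N)nc(Nc2ccc(C#N)cc2)n1` gives 76700 nM
compound 2 `Cc1cc(-c2ccc(C#N)c(F)c2)cc(C)c1Oc1cc(N)nc(Nc2ccc(C#N)cc2)n1` gives 5000 nM
compound 3 `Cc1cc(-c2cccc(C#N)c2)ccc1Oc1cc(N)nc(Nc2ccc(C#N)cc2)n1` gives 27400 nM

Compound 3, at 27400 nM, is the second highest of the three numbers. Compound 1 stands higher at 76700 nM, and compound 2 stands lowest at 5000 nM.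

The next compound is compound 4 `Cc1cc(-c2ccc(C#N)c(F)c2)ccc1Oc1cc(N)nc(Nc2ccc(C#N)cc2)n1`. It carries 4-cyano-3-fluorophenyl in place of 3-cyanophenyl on an aromatic carbon.

Among the compounds with values here, only one measured step changes this same aryl group: a 2.8-fold lower number from compound 1 to compound 3 (0.45 log units; beyond the scatter). It is modest, and it involves a different exchange, so it gives a rough scale rather than a direct precedent. Within the data shown here, compound 2, at 5000 nM, already carries the 4-cyano-3-fluorophenyl group but differs from compound 4 elsewhere, and no step isolates that difference. With so little direct evidence, a modest move to a lower number in this assay is expected, possibly no larger than the scatter.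

The estimated step is a 1.8-fold lower number from compound 3 to compound 4 (0.26 log units; within the scatter). For compound 4 the estimated value is 15000 nM, with an expected range of 5000 nM to 40000 nM.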

Compound 4, half-maximal cytotoxic concentration: 6600 nM
For compound 4 the middle estimate is 2.3-fold (0.36 log units) above the measured one; low and high end bracket the measured number.
By their numbers in this assay, from the lowest: compounds 2 and 4 (each within the scatter of the next); then compound 3; then compound 1.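

In this assay, swapping the aryl group at this position moves the number further than the earlier change on this ring, a 2.8-fold lower number from compound 1 to compound 3 (0.45 log units; beyond the scatter), did: the new group gives a 4.2-fold lower number from compound 3 to compound 4 (0.62 log units; beyond the scatter) and also a 12-fold lower number from compound 1 to compound 4 (1.07 log units; beyond the scatter), so among the three aryl groups on this core, 4-cyano-3-fluorophenyl stands lowest, with both steps beyond the scatter. The step of a 1.3-fold higher number from compound 2 to compound 4 (0.12 log units; within the scatter) lies within the scatter, so with 4-cyano-3-fluorophenyl in place, hydrogen for methyl on the other ring leaves no readable change in this assay. Compound 2 and compound 4 therefore sit together at the low end of the set, and the aryl group, not that methyl, is the change that separates compound 4 from compound 1 and compound 3.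

From the compounds shown here alone, compound 4 differs from compound 3 both by the added fluoro and by where the nitrile stands, so the two contributions stay unseparated, and how a chloro or a methoxy group in the place of that fluoro would read remains open. No measurement shown here accounts for these shifts in tolerated concentration.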